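Methoxy in Place of Chloro on the Aryl Substituent

The source may report more compounds than this note shows. Statements on the series, on what has been measured and on what is new or still open speak of the compounds shown alone.

Compound 1 `O=C1CNc2nc(Nc3ccccc3)ncc2N1` reaches only a limit in a functional assay on BT-549 cells (Homo sapiens) for cytotoxicity, read by MTT assay, with a stated time of 48 h (on this read-out higher numbers stand for weaker inhibition and lower numbers for stronger inhibition), where compound 1 gives > 100000 nM. Going by the values given here, compound 2 `O=C1CNc2nc(Nc3ccc(Cl)cc3)ncc2N1` gives 17700 nM in this assay, the only number among the values shown. The step of an at least 5.6-fold lower number from compound 1 to compound 2 (0.75 log units; beyond the scatter) is the sole measured one, and it shows that a group at this carbon can move the number well beyond the scatter. Compound 3 `COc1ccc(Nc2ncc3c(n2)NCC(=O)N3)cc1` differs from compound 2 in one place: methoxy in place of chloro on an aromatic carbon. Going by these compounds, whether methoxy acts like chloro is untested, so a modest weakening is expected. Compound 3 is estimated at 40000 nM (between 15000 nM and 100000 nM) in this assay. The expected step is a 2.3-fold higher number from compound 2 to compound 3 (0.35 log units; beyond the scatter).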

Compound 3, half-maximal inhibitory concentration: 95000 nM
Compound 3: the middle estimate sits 2.4-fold (0.38 log units) below what was measured; low and high end bracket the measured number.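

In this assay, what counts at this aromatic carbon is which group sits there, not merely that hydrogen has been replaced: methoxy does not keep the level reached with chloro, giving a 5.4-fold higher number from compound 2 to compound 3 (0.73 log units; beyond the scatter). Against hydrogen, methoxy gives an at least 1.0-fold lower number from compound 1 to compound 3 (0.02 log units; that floor lies within the scatter), and that floor does not set the two compounds apart. Compound 1 stands at a limit of the assay, which leaves this comparison unresolved: the limit of > 100000 nM in this assay, at which 1 of the 3 values shown sits.

The compounds shown leave open whether bromo, an amine or a carboxylic acid at this carbon would match chloro or fall back towards methoxy.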